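The source may hold more compounds than are shown below. What is called first, only, known or untested is meant among the compounds shown, and "the series" means these compounds.

Measured so far:
- compound 1, `CC[C@H](C)[C@H](NS(=O)(=O)c1cc(Br)c(Br)s1)C(=O)N[C@@H](CNC(=O)OCc1ccccc1)C(=O)NO`: 52 nM in an assay on isolated protein for inhibition of bone morphogenetic protein 1 (Homo sapiens); a lower number here means a stronger inhibitor, a higher number a weaker inhibitor
- compound 2, `CC[C@@H](C)[C@@H](NC(=O)OCc1ccccc1)C(=O)NCC(NCc1ccccc1)C(=O)NO`: 94 nM in this assay

Within the data shown here, only two compounds have numbers. Compound 2 carries the larger of the two, with compound 1 as its nearest neighbour, and the gap between them lies within the usual scatter of repeated measurements, so nothing can be read from it about a difference in potency. Among the measured compounds shown here, no step between measured compounds that differ in one place exists in this set.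

Compound 3, `CC[C@@H](C)[C@@H](NC(=O)OCc1ccccc1)C(=O)NCC(NC(=O)OCc1ccccc1)C(=O)NO`, has not yet been measured in this assay. It differs from compound 2 in one place: benzyloxycarbonyl in place of benzyl on an amine nitrogen. After this change the amine nitrogen of compound 3 carries the same benzyloxycarbonyl group that sits on the corresponding amine of compound 1, which gives 52 nM; the left-hand part of compound 3 remains that of compound 2. Since compound 1 and compound 2 lie within the scatter of each other, no step beyond the scatter is expected from compound 2 to compound 3, and the expected step of a 1.3-fold lower number from compound 2 to compound 3 (0.13 log units; within the scatter) is small. Compound 3 is estimated at 70 nM, with a range from 25 nM to 200 nM.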

Compound 3, half-maximal inhibitory concentration: 61 nM
Beside the measured number, compound 3's estimate is 1.1-fold (0.06 log units) above it, within the range that was stated.
By their numbers in this assay, from the lowest: compounds 1, 3 and 2 (each within the scatter of the next).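

In this assay, among these compounds, benzyloxycarbonyl in place of benzyl on an amine nitrogen gives a 1.5-fold lower number from compound 2 to compound 3 (0.19 log units; within the scatter) and is the first step that can be read at one place. At this position the two groups cannot be told apart on this read-out, even though benzyloxycarbonyl has 10 heavy atoms and 2 hydrogen-bond acceptors against 7 heavy atoms and 0 hydrogen-bond acceptors for benzyl, and both keep one six-membered aromatic ring. No measurement at hand bears on why the two groups read alike.

As far as these compounds go, the bare amine, an acetyl group and a phenethyl group on this nitrogen remain open, so the pair does not show whether the aromatic ring is needed here or how far a longer chain would be tolerated. From the compounds shown here alone, the carbamate on the other amine nitrogen also remains open, since a sulfonamide such as the dibromothiophene sulfonyl group of compound 1 has yet to be compared with it in a pair that differs only in that one place.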